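Benzyl-substituted halogen series: clearance notes toward compound 4

The compounds below may be only part of what the source reports. "The series", "measured", "known", "first", "only" and "open" are said of these compounds alone.

Measured in an ADME assay on microsomes from liver (Rattus norvegicus, strain Wistar) for metabolic stability, tested at 2.5 uM; on this read-out higher numbers stand for fast clearance and lower numbers for slow clearance:
- compound 1, `Brc1cccc2c1nnn2Cc1ccccc1`: 2 mL/min/g
- compound 2, `Fc1ccc(Cn2nnc3c(Br)cccc32)cc1`: 1 mL/min/g
- compound 3, `Brc1ccc(Cn2nnc3c(Br)cccc32)cc1`: 2.2 mL/min/g

Compound 2 has the lowest number of the three in this assay. Its nearest neighbour is compound 1, a 2.0-fold lower number from compound 1 to compound 2 (0.30 log units; within the scatter), so the two are not separated. Against compound 3 the gap is a 2.2-fold higher number from compound 2 to compound 3 (0.34 log units; beyond the scatter), a modest separation. The remaining step, a 1.1-fold higher number from compound 1 to compound 3 (0.04 log units; within the scatter), shows that bromo in place of hydrogen on the benzyl ring left the number where it was.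

Compound 4, `Fc1ccc(Cn2nnc3c(Br)cccc32)c(Cl)c1`, is not yet measured. It differs from compound 2 as follows: chloro in place of hydrogen on an aromatic carbon. The change is chloro in place of hydrogen on an aromatic carbon, ortho to a large group and meta to the fluoro group.

Going by the values given here, the steps that bear on it are those adding or exchanging a halogen on the benzyl ring. Bromo in place of hydrogen gave a step within the scatter, and bromo in place of fluoro gave a modest rise. A second halogen on the ring is therefore expected to move the number little, perhaps slightly upward: a 1.4-fold higher number from compound 2 to compound 4 (0.15 log units; within the scatter) is the expected step. Compound 4 is estimated at 1.4 mL/min/g, within 0.7 mL/min/g to 2.8 mL/min/g.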

Compound 4, intrinsic clearance in a liver preparation (reported as CLH), per the amount of preparation that the assay uses: 3.5 mL/min/g
Compound 4: the middle estimate sits 2.5-fold (0.40 log units) below what was measured, and the stated range ends below it.
By their numbers in this assay, from the lowest: compounds 2, 1, 3 and 4 (each within the scatter of the next, the first and the last beyond it).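

In this assay chloro in place of hydrogen on the aromatic carbon ortho to a large group and meta to a fluoro group gives a 3.5-fold higher number from compound 2 to compound 4 (0.54 log units; beyond the scatter) as a modest step, so this carbon is a place on the ring where a single added halogen moves the number beyond the scatter. The earlier additions of a halogen to the benzyl ring, a 2.0-fold lower number from compound 1 to compound 2 (0.30 log units; within the scatter) and a 1.1-fold higher number from compound 1 to compound 3 (0.04 log units; within the scatter), both stayed within the scatter, and neither of them touched this carbon, so they could not show this. The rise also takes the series away from compound 2, which until now held the lowest number, and it shows that the fluoro group present on the ring does not keep the number low once chloro enters at this carbon. Nothing available accounts for the step.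

Open, going by these compounds, is whether the rise belongs to chloro itself or to any group at this carbon, which a methyl group, a methoxy group or an amine in the same place would test. Also open, on these data alone, is whether chloro at this carbon gives a step of similar size on the ring without the fluoro group.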